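The source may report more compounds than this note shows. Statements on the series, on what has been measured and on what is new or still open speak of the compounds shown alone.

Compound 1 `CN(C)c1ccc(C2CC(c3ccccc3)=NN2C2=NC(=O)/C(=C3\C(=O)Nc4ccc(Br)cc43)S2)cc1` and compound 2 `CN(C)c1ccc(C2CC(c3ccccc3)=NN2C2=NC(=O)/C(=C3\C(=O)Nc4ccc(Cl)cc43)S2)cc1` share one core; compound 3 `COc1ccc(-c2cc(-c3ccc(Cl)cc3)n(C3C(=O)Nc4ccc(Br)cc43)n2)cc1` and compound 4 `COc1ccc(-c2cc(-c3ccc(Cl)cc3)n(C3C(=O)Nc4ccc(Cl)cc43)n2)cc1` share another, and the difference between the two cores is not broken down here. In a functional assay on cells (Leukemia cell, Homo sapiens) for cytotoxicity, read by sulforhodamine B assay, with a stated time of 48 h (a higher number here means a weaker inhibitor of growth, a lower number a stronger inhibitor of growth), compound 1 gives 1290 nM, while compound 2 gives 3110 nM; the step of a 2.4-fold higher number from compound 1 to compound 2 (0.38 log units; beyond the scatter) follows the change (chloro in place of bromo on an aromatic carbon). Compound 3 gives 67000 nM in this assay, the highest number of the three. The same change, (chloro in place of bromo on an aromatic carbon), leads from compound 3 to compound 4. Because the step of a 2.4-fold higher number from compound 1 to compound 2 (0.38 log units; beyond the scatter) was modest, a step of similar size and direction is expected for compound 4, with wider uncertainty since the cores differ. Compound 4 is therefore estimated at 110000 nM in this assay, between 45000 nM and 300000 nM, a step of a 1.6-fold higher number from compound 3 to compound 4 (0.22 log units; within the scatter).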

Compound 4, concentration for total growth inhibition: 79200 nM
Compound 4: the middle estimate sits 1.4-fold (0.14 log units) above what was measured; the measured number falls inside the stated range.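

Chloro in place of bromo on an aromatic carbon gives a 1.2-fold higher number from compound 3 to compound 4 (0.07 log units; within the scatter) in this assay. Set beside the earlier step on the other core, this step cannot be told apart from it: the same change on two cores in this assay, a 2.4-fold higher number (0.38 log units; beyond the scatter) from compound 1 to compound 2 and a 1.2-fold higher number (0.07 log units; within the scatter) from compound 3 to compound 4, 2.0-fold (0.31 log units) apart, within the scatter of two such steps This suggests that the change carries across these two cores without a clear difference in size, but it rests on only one pair per core, and the step on the core of compound 3 is itself within the scatter, so it shows no real difference between bromo and chloro there and says nothing about any further core. The compounds shown leave open what fluoro, methyl, an amine or a carboxylic acid would do at this aromatic carbon on either core.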